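Amide nitrogen substitution in the CDK8 series: compound 4

The source may report more compounds than this note shows. Statements on the series, on what has been measured and on what is new or still open speak of the compounds shown alone.

Compound 2 `CNC(=O)CCc1ccncc1-c1ccc2ccccc2c1` gives 100% in an assay on a protein complex for inhibition of CDK8/Cyclin C (Homo sapiens), with a stated time of 1 h, tested at 10 uM (a higher number here means more inhibition at the concentration tested (going by the name of the read-out), a lower number less inhibition), and the two measured neighbours lie within the usual scatter of it: compound 1 `NC(=O)/C=C/c1ccncc1-c1ccc2ccccc2c1` gives 102% and compound 3 `O=C(/C=C/c1ccncc1-c1ccc2ccccc2c1)NC1CC1` gives 102%. Compound 4 `O=C(CCc1ccncc1-c1ccc2ccccc2c1)N1CCOCC1` differs from compound 2 by morpholin-4-yl in place of methylamino on a carbonyl carbon. The steps that touch the amide end are all flat: a number 2 percentage points lower from compound 1 to compound 2 (within the scatter), no change at the digits printed from compound 1 to compound 3 (within the scatter) and a number 2 percentage points higher from compound 2 to compound 3 (within the scatter), so enlarging the group on the amide nitrogen has not moved this assay beyond the scatter. The step to compound 4 is therefore expected to be a number 1 percentage points lower from compound 2 to compound 4 (within the scatter), no change beyond the scatter. Compound 4 is estimated at 99%, within 88% to 106%.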

Compound 4, a percentage reported as inhibition, at one concentration (the size of the read-out at that concentration, not a potency): 100%
The estimate for compound 4 lay 1 percentage points below the measured number; the range from low to high includes it.
By their numbers in this assay, from the lowest: compounds 2, 4, 1 and 3 (each within the scatter of the next).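

In this assay, morpholin-4-yl in place of methylamino on a carbonyl carbon gives no change at the digits printed from compound 2 to compound 4 (within the scatter). Compound 4 alone among the compounds shown has no hydrogen-bond donor on the amide and carries a six-membered non-aromatic ring there, yet its read-out stays within the scatter of compound 2. No available evidence accounts for this result.

Going by these compounds, whether a carboxylic acid or a primary amine at this place would hold the read-out remains open. The single-concentration read-out also leaves open whether compound 2 and compound 4 differ in potency.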